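The compounds below may be only part of what the source reports. "The series", "measured", "known", "first", "only" and "open" are said of these compounds alone.

In a functional assay on HepG2 cells (Homo sapiens) for inhibition, read by MTT assay (a lower number here means a stronger inhibitor, a higher number a weaker inhibitor), compound 1 `COc1cc2ncnc(Nc3ccc(NC(=O)c4ccccc4OC)cc3)c2cc1OC` reaches only a limit, > 100000 nM, and not a number. Among the compounds with values here, compound 2 `COc1cc2ncnc(Nc3ccc(NC(=O)c4ccc(Br)cc4)cc3)c2cc1OC`, which carries a 4-bromophenyl on the carbonyl carbon, gives 35000 nM, the only actual number so far in this assay. Compound 3 `COc1cc2ncnc(Nc3ccc(NC(=O)c4ccc(C(F)(F)F)cc4)cc3)c2cc1OC` keeps everything else and has trifluoromethyl in place of bromo on an aromatic carbon, para to a large group (trifluoromethyl in place of bromo on an aromatic carbon). Within the data shown here, only one measured step bears on this change: an at least 2.8-fold lower number from compound 1 to compound 2 (0.45 log units; beyond the scatter), with 4-bromophenyl in place of 2-methoxyphenyl. That step lies beyond the scatter, but it rests on a limit and exchanges a different pair of groups. It shows that the group on the carbonyl carbon can matter, yet it gives no direction for replacing bromo with trifluoromethyl. With compound 2 at 35000 nM as the only anchor, no step beyond the scatter is expected in this assay. The expected change is a 1.1-fold higher number from compound 2 to compound 3 (0.06 log units; within the scatter). For compound 3 the estimated value is 40000 nM, with an expected range from 15000 nM to 100000 nM.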

Compound 3, half-maximal inhibitory concentration: > 100000 nM
Compound 3: only a limit was reported (the forecaster's own chance of this, stated with the estimate: 20%); middle value at least 2.5-fold (0.39 log units) from the limit.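

The step of an at least 2.8-fold higher number from compound 2 to compound 3 (0.45 log units; beyond the scatter) isolates the group on the aromatic carbon, para to a large group, in this assay. The earlier step exchanged a whole 2-methoxyphenyl for a 4-bromophenyl, whereas this one keeps the phenyl and changes only bromo to trifluoromethyl, so it shows that having a group at this place is not enough to give a measurable number: among the compounds shown, that number goes with bromo. Compound 2 remains the only compound with an actual number, so this reading rests on a single value set against limits: the limit of > 100000 nM in this assay, at which 2 of the 3 values shown sit.

From the compounds shown here alone, the step between compound 1 and compound 3 cannot be read, as both values are limits, and how far compound 3 lies past its limit also stays unknown. Going by these compounds, it remains open whether chloro, methyl or a nitrile at this same place would give a number like that of compound 2, and whether any group here could bring the number well below that of compound 2.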